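The source may report more compounds than this note shows. Statements on the series, on what has been measured and on what is new or still open speak of the compounds shown alone.

- Compound 1 `OC[C@H]1O[C@@H](n2cnc3c(NCc4ccccc4Br)ncnc32)[C@H](O)[C@@H]1O`: > 166000 nM (a limit of the assay, not a number)
- Compound 2 `OC[C@H]1O[C@@H](n2cnc3c(NCc4ccc(Cl)cc4Cl)ncnc32)[C@H](O)[C@@H]1O`: 127000 nM

For the measured compounds named here, in a functional assay on MCF cells (Homo sapiens) for antiproliferative activity, with a stated time of 72 h (on this read-out higher numbers stand for weaker inhibition and lower numbers for stronger inhibition), compound 2 gives 127000 nM, the only true number so far. The other result, (the limit of > 166000 nM in this assay, at which 1 of the 2 values shown sits), belongs to compound 1 and is a limit. The one measured step is an at least 1.3-fold lower number from compound 1 to compound 2 (0.11 log units; that floor lies within the scatter), so swapping this group has not yet shown a clear effect. Compound 3 `COc1cccc(CNc2ncnc3c2ncn3[C@@H]2O[C@H](CO)[C@@H](O)[C@H]2O)c1OC` changes the same place: 2,3-dimethoxyphenyl in place of 2,4-dichlorophenyl on a saturated chain carbon bound to a nitrogen on an aromatic ring. Going by the values given here, with only that step to go on, the expected result in this assay is a 1.1-fold higher number from compound 2 to compound 3 (0.04 log units; within the scatter), with no direction expected beyond the scatter. For compound 3 the estimated value is 140000 nM, within an expected range of 60000 nM to 320000 nM.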

Compound 3, half-maximal inhibitory concentration: > 166000 nM
Compound 3 gave a limit, no number; the forecaster's own chance of this, stated with the estimate: 40%; at least 1.1-fold (0.07 log units) between middle value and limit.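

In this assay, placing 2,3-dimethoxyphenyl where 2,4-dichlorophenyl stood, on a saturated chain carbon bound to a nitrogen on an aromatic ring, gives an at least 1.3-fold higher number from compound 2 to compound 3 (0.11 log units; that floor lies within the scatter), so a second change at this position also shows no clear effect. The result for compound 3 is a limit, not a number, and the step from compound 1 to compound 3 cannot be read. Only one true number now stands at this position, with the other results at the same limit: the limit of > 166000 nM in this assay, at which 2 of the 3 values shown sit.

As far as these compounds go, whether an amine or a carboxylic acid in place of the substituted phenyl ring would give a number clearly lower than compound 2 stays open.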